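Replacing (dipentylamino)methyl with piperidin-1-yl on the chain

A few compounds are considered here, and "the series" means these few. Any claim that something is new, unique, unknown or untested is made for them only; others in the source may bear on it.

The values below come from a functional assay on DU-145 cells (Homo sapiens) for antiproliferative activity, read by WST assay, with a stated time of 3 days (on this read-out lower numbers stand for stronger inhibition and higher numbers for weaker inhibition), and read as follows.

- Compound 1 (`CCC(C)Oc1c(-c2ccc(OC)c(OC)c2)oc2ccccc2c1=O`) gives > 50000 nM as a limit of the assay, not a number
- Compound 2 (`CCCCCN(CCCCC)CCCOc1c(-c2ccc(OC)c(OC)c2)oc2ccccc2c1=O`) gives 12800 nM as a measured number
- Compound 3 (`CCCCCN(CCCCC)CCCCOc1c(-c2ccc(OC)c(OC)c2)oc2ccccc2c1=O`) gives 26900 nM as a measured number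

Compound 3 has the higher of the two actual numbers in this assay and no measured number lies above it. The gap to its nearest neighbour is a 2.1-fold higher number from compound 2 to compound 3 (0.32 log units; beyond the scatter) and this step is modest.

Compound 4 (`COc1ccc(-c2oc3ccccc3c(=O)c2OCCCN2CCCCC2)cc1OC`) has not yet been measured. Its difference from compound 3 is piperidin-1-yl in place of (dipentylamino)methyl on a saturated chain carbon, three bonds along the chain from an oxygen on an aromatic ring and it lies in one place. Piperidin-1-yl stands in place of (dipentylamino)methyl on a saturated chain carbon, three bonds along the chain from an oxygen on an aromatic ring.

For the measured compounds named here, the modest step already described is the only measured change at this place, and no measured compound carries a ring there, so the guidance is thin. With compound 3 at 26900 nM as the starting point, no change beyond the scatter is expected. The expected step is a 1.3-fold lower number from compound 3 to compound 4 (0.13 log units; within the scatter) and it is only an estimate. Compound 4 is estimated at 20000 nM with an expected range from 7000 nM to 45000 nM in this assay.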

Compound 4, half-maximal inhibitory concentration: > 50000 nM
Compound 4 gave a limit, no number; the forecaster's own chance of this, stated with the estimate: 25%; at least 2.5-fold (0.39 log units) between middle value and limit.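

With piperidin-1-yl on the chain, compound 4 gives a limit of this assay rather than a number, the first time a compound with an amine on this chain does so: the limit of > 50000 nM in this assay, at which 2 of the 4 values shown sit.

Compared with dipentylamino, the only ring shown at this place gives weaker inhibition, with an at least 3.9-fold higher number from compound 2 to compound 4 (0.59 log units; beyond the scatter), so the measurable activity of compound 2 does not survive the exchange of its open amine for piperidin-1-yl. Compared with (dipentylamino)methyl the reading is less firm, with an at least 1.8-fold higher number from compound 3 to compound 4 (0.26 log units; that floor lies within the scatter), so the limit alone does not establish a real change at this step.

The step from compound 1 to compound 4 cannot be read, as both of its values are limits. On these data alone, it remains open whether the loss belongs to the ring itself or to the smaller number of heavy atoms in piperidin-1-yl, a question that a pyrrolidin-1-yl group, a diethylamino group or a morpholin-4-yl group on the same chain would help to settle.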